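Oxane substituents and the unsaturated analogue, compound 4

This account rests on a few compounds, and the source may have more. Where it says the series, first, only, none or still open, it means among the compounds named here.

In an ADME assay on microsomes from liver (Rattus norvegicus) for metabolic stability, with a stated time of 10 min (on this read-out lower numbers stand for a less stable compound and higher numbers for a more stable compound), compound 1 `COc1ccccc1-n1nc(C2CCOC(C)(C)C2)cc1-c1ccc(Cl)cc1` gives 21%. Compound 2 `COc1ccccc1-n1nc(C2C[C@H](C)O[C@@H](C)C2)cc1-c1ccc(Cl)cc1` gives 14%, and compound 3 `COc1ccccc1-n1nc([C@@H]2CCO[C@H](C(C)C)C2)cc1-c1ccc(Cl)cc1` gives 21%. Compound 1 is level with compound 3 and within the usual scatter of compound 2, so the three numbers do not separate.

For the measured compounds named here, two measured steps bear on the same place on the core. The 2,6-dimethyloxan-4-yl group gives a number 7 percentage points lower from compound 1 to compound 2 (within the scatter), and the 2-isopropyloxan-4-yl group gives no change at the digits printed from compound 1 to compound 3 (within the scatter). Neither step leaves the scatter.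

Compound 4 `COc1ccccc1-n1nc(C2=CC(C)(C)OC(C)(C)C2)cc1-c1ccc(Cl)cc1` has not yet been measured. Its difference from compound 1 is a group of 10 heavy atoms (9 carbon, 1 oxygen; one six-membered non-aromatic ring with 1 hetero atom) in place of a group of 8 heavy atoms (7 carbon, 1 oxygen; one six-membered non-aromatic ring with 1 hetero atom), on an aromatic carbon. Going by the values given here, the entering group also has 1 double bond outside aromatic rings, and no measured compound carries such a group, so the measured steps offer only a weak guide.

On the small steps seen with compound 2 and compound 3, no change beyond the scatter is expected, and the estimated step is a number 1 percentage points lower from compound 1 to compound 4 (within the scatter). For compound 4 the expected value is 20%, with an estimated range of 8% to 35%.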

Compound 4, percent of the compound remaining: 37%
Compound 4: the middle estimate sits 17 percentage points below what was measured; measured number above the stated range.
By their numbers in this assay, from the lowest: compounds 2, 1 and 3 (each within the scatter of the next); then compound 4.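

For the compounds shown here, with the entering group, which carries 1 double bond outside aromatic rings and 10 heavy atoms, the numbers move as follows: a number 16 percentage points higher from compound 1 to compound 4 (beyond the scatter) and a number 16 percentage points higher from compound 3 to compound 4 (beyond the scatter) and a number 23 percentage points higher from compound 2 to compound 4 (beyond the scatter) in this assay and these are the first steps at this position to leave the scatter. This place on an aromatic carbon can therefore register a change in this read-out, although the substituents of compound 1, compound 2 and compound 3 did not separate. No supporting measurement accounts for the rise.

The double bond and the added carbons change together here, so a 2,2,6,6-tetramethyloxan-4-yl group would be needed to tell them apart. From the compounds shown here alone, whether the ring oxygen matters also stays open, and a piperidine ring with its amine nitrogen in that place would address it.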